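Hexylamino versus methylamino on two related cores

The source may hold more compounds than are shown below. What is called first, only, known or untested is meant among the compounds shown, and "the series" means these compounds.

Measured compounds:
compound 1, `CCCCCCNc1[nH]ccc2ncnc1-2`, 100%
compound 2, `CNc1[nH]ccc2ncnc1-2`, < 5%
compound 3, `CNc1nccc2c1ncn2C1O[C@H](CO)[C@@H](O)[C@H]1O`, 11%

In a functional assay on EL4 cells (Mus musculus) for inhibition, tested at 100 uM (a higher number here means more inhibition at the concentration tested (going by the name of the read-out), a lower number less inhibition), compound 1 gives 100%. For compound 2 the read-out is only a limit of the assay, < 5%; this is the limit of < 5% in this assay, at which 1 of the 3 values shown sits. Compound 3 gives 11% in this assay, which is the lowest of the numbers reported and stands far under compound 1.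

The step from compound 2 to compound 1 is pentyl in place of hydrogen on a saturated chain carbon bound to a nitrogen on an aromatic ring; it gives a number at least 95 percentage points higher from compound 2 to compound 1 (beyond the scatter). Compound 3 and compound 2 share the methylamino group but carry different cores; the difference between the two cores is not broken down here.

Compound 4, `CCCCCCNc1nccc2c1ncn2C1O[C@H](CO)[C@@H](O)[C@H]1O`, has not been measured in this assay. It differs from compound 3 by pentyl in place of hydrogen on a saturated chain carbon bound to a nitrogen on an aromatic ring, the same change as from compound 2 to compound 1. For compound 4 the step of a number 74 percentage points higher from compound 3 to compound 4 (beyond the scatter) is expected, resting on compound 3 at 11% and on the large step from compound 2 to compound 1, a number at least 95 percentage points higher from compound 2 to compound 1 (beyond the scatter), while the cores of compound 1 and compound 4 are not the same, so a smaller step is kept within the range. Compound 4 is estimated at 85% in this assay, between 50% and 100%.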

Compound 4, a percentage reported as inhibition, at one concentration (the size of the read-out at that concentration, not a potency): 14%
Compound 4: the middle estimate sits 71 percentage points above what was measured; the measured number lies below the stated range.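

Carrying the change from methylamino to hexylamino onto the core of compound 3 does not repeat the result seen on the core of compound 1: in this assay it gives a number 3 percentage points higher from compound 3 to compound 4 (within the scatter). In these two pairs, the size of the step therefore depends on the core: the same change on two cores in this assay, a number at least 95 percentage points higher (beyond the scatter) from compound 2 to compound 1 and a number 3 percentage points higher (within the scatter) from compound 3 to compound 4, at least 92 percentage points apart, beyond the scatter of two such steps This does not show which feature of the cores accounts for the gap, and one pair on each core gives no rule for other chains or other cores in the series.

Still open, as far as these compounds go, is how the read-out moves with chains of intermediate length on either core, and whether a longer chain such as octyl, or a hexyl chain ending in an amine or a carboxylic acid, would give a step beyond the scatter on the core of compound 3. Also open, from the compounds shown here alone, is which single structural difference between the two cores decides the outcome, since the cores of compound 1 and compound 4 differ in more than one place.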